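Ester to thioester on the sulfonylacetyl anilide core

A few compounds are considered here, and "the series" means these few. Any claim that something is new, unique, unknown or untested is made for them only; others in the source may bear on it.

Compound 1 `CC(C)c1cccc(C(C)C)c1NS(=O)(=O)CC(=O)N(Cc1ccccc1)C(C)C`: in an assay on microsomes from intestine for inhibition of acyl-CoA:cholesterol acyltransferase (Oryctolagus cuniculus) (a lower number here means a stronger inhibitor, a higher number a weaker inhibitor), compound 1 gives 150 nM.
Compound 2 `CCCCCCCCOC(=O)CS(=O)(=O)Nc1c(C(C)C)cccc1C(C)C`: in this assay compound 2 gives only a limit, > 1000 nM.

Compound 2 stands at the limit of > 1000 nM in this assay, at which 1 of the 2 values shown sits, so no number beyond that limit is known for it. Compound 3 `CCCCCCCCSC(=O)CS(=O)(=O)Nc1c(C(C)C)cccc1C(C)C` differs from compound 2 by octylsulfanyl in place of octyloxy on a carbonyl carbon. For the measured compounds named here, no measured pair carries this change, so the data give no step size in this assay; the expectation is a step of no more than the usual scatter, in no firm direction. Compound 3 is therefore expected near 1500 nM, within 500 nM to 5000 nM. The estimated step is a step that the limit leaves unreadable from compound 2 to compound 3.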

Compound 3, half-maximal inhibitory concentration: 150 nM
Compound 3: middle estimate off by 10-fold (1.00 log units), on the high side; measured number outside the range, below it.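

Octylsulfanyl in place of octyloxy on a carbonyl carbon gives an at least 6.6-fold lower number from compound 2 to compound 3 (0.82 log units; beyond the scatter) in this assay. With the octyl chain and the shared core unchanged, the atom linking that chain to the carbonyl carbon clearly matters in this series. The full size of the step remains unknown, since compound 2 carries a limit and not a number: the limit of > 1000 nM in this assay, at which 1 of the 3 values shown sits.

Open, going by these compounds, is whether an octylamino group on the same carbonyl carbon would match octylsulfanyl. Also open, on these data alone, is how a hexyl or decyl chain on the sulfur would compare with the octyl chain.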